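Adding trifluoromethyl to a weakly cytotoxic amine

The compounds below may be only part of what the source reports. "The series", "measured", "known", "first", "only" and "open" are said of these compounds alone.

compound 1 `COc1c(-c2ccccc2)oc2ccc(N)cc2c1=O`: 74000 nM
compound 2 `COc1c(-c2ccc(F)cc2)oc2ccc(N)cc2c1=O`: 36000 nM
compound 3 `COc1c(-c2cccc(C(F)(F)F)c2)oc2ccc(N)cc2c1=O`: not yet measured

Among the measured compounds shown here, in an ADME assay on THP-1 cells (Homo sapiens) for cytotoxicity, read by flow cytometry and propidium iodide staining, with a stated time of 72 h (on this read-out lower numbers stand for stronger inhibition and higher numbers for weaker inhibition), compound 1 gives 74000 nM, the highest of the two numbers measured so far. Compound 3 differs from it by one change: trifluoromethyl in place of hydrogen on an aromatic carbon. The new group stands on an aromatic carbon of the six-membered ring, meta to a large group. For the measured compounds named here, one measured step bears on this, a fluoro in place of hydrogen on an aromatic carbon, which gave a 2.1-fold lower number from compound 1 to compound 2 (0.31 log units; beyond the scatter). That step is modest and rests on a single pair, so it offers only a loose guide. A step of similarly modest size towards a lower number is therefore expected in this assay, although the data cannot exclude one within the scatter. For compound 3 the estimated value is 32000 nM, with an expected range from 11000 nM to 85000 nM. This estimate corresponds to an expected 2.3-fold lower number from compound 1 to compound 3 (0.36 log units; beyond the scatter).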

Compound 3, half-maximal inhibitory concentration: 33000 nM
Beside the measured number, compound 3's estimate is 1.0-fold (0.01 log units) below it; the measured number falls inside the stated range.
By their numbers in this assay, from the lowest: compounds 3 and 2 (each within the scatter of the next); then compound 1.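

In this assay, trifluoromethyl in place of hydrogen on this aromatic carbon, meta to a large group, gives a 2.2-fold lower number from compound 1 to compound 3 (0.35 log units; beyond the scatter), so this position tolerates a substituent of four heavy atoms without losing the modest downward move. Together with the fluoro change, which gave a 2.1-fold lower number from compound 1 to compound 2 (0.31 log units; beyond the scatter), this makes two different substituents on the phenyl ring that each lower the number modestly, though compound 3 still gives 33000 nM, and two steps do not yet make a trend. Nothing in the data accounts for either step.

The compounds shown leave open whether a carboxylic acid or an amine on the same carbon would move the number the other way. They also leave open whether methoxy or a longer alkyl chain there would give a step of a different size.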